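A dimethoxyphenyl swap among results stuck at a limit

A few compounds are considered here, and "the series" means these few. Any claim that something is new, unique, unknown or untested is made for them only; others in the source may bear on it.

In a functional assay on HOS cells (Homo sapiens) for antiproliferative activity, with a stated time of 72 h (on this read-out higher numbers stand for weaker inhibition and lower numbers for stronger inhibition), compound 1 (`OC[C@H]1O[C@@H](n2cnc3c(NCc4ccc(Cl)cc4Cl)ncnc32)[C@H](O)[C@@H]1O`) gives > 166000 nM as a limit, not a number. Compound 2 (`OC[C@H]1O[C@@H](n2cnc3c(NCc4ccc(Cl)c(Cl)c4)ncnc32)[C@H](O)[C@@H]1O`) gives > 166000 nM as a limit too. Compound 3 (`COc1cccc(CNc2ncnc3c2ncn3[C@@H]2O[C@H](CO)[C@@H](O)[C@H]2O)c1OC`) gives > 166000 nM as a limit as well, so it has no exact place on the scale. All three results agree: the limit of > 166000 nM in this assay, at which 3 of the 3 values shown sit, is the whole picture so far.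

Compound 4 (`COc1ccc(CNc2ncnc3c2ncn3[C@@H]2O[C@H](CO)[C@@H](O)[C@H]2O)c(OC)c1`) has the same atoms as compound 3, joined differently, with 2,4-dimethoxyphenyl in place of 2,3-dimethoxyphenyl on a saturated chain carbon bound to a nitrogen on an aromatic ring.

The measured steps change this same group, but none has a readable size: there is a step that the two limits leave unreadable from compound 1 to compound 2 and a step that the two limits leave unreadable from compound 1 to compound 3 and also a step that the two limits leave unreadable from compound 2 to compound 3 to go on. For the measured compounds named here, with the limit of > 166000 nM in this assay, at which 3 of the 3 values shown sit, as the only guide, no step beyond the scatter is expected in this assay in either direction. The estimated change is a step that the limit leaves unreadable from compound 3 to compound 4 at most a small one. The estimate for compound 4 is 200000 nM within an expected range of 100000 nM to 400000 nM and the assay will probably report only a limit again.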

Compound 4, half-maximal inhibitory concentration: > 166000 nM
Compound 4: a limit, no number; the forecaster's own chance of this, stated with the estimate: 85%; the middle value lies beyond the limit too.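

Compound 4 also gives only a limit, like compound 1, compound 2 and compound 3, so no step among these four can be read in this assay. The compounds shown leave open how strongly any of them inhibits, and whether changing the phenyl group alters that at all: the limit of > 166000 nM in this assay, at which 4 of the 4 values shown sit.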